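This account rests on a few compounds, and the source may have more. Where it says the series, first, only, none or still open, it means among the compounds named here.

Compound 1 `COc1ccc(-n2cc(-c3ccc(OC)c(OC)c3)nn2)cc1O`: > 1000 nM in a functional assay on MDA-MB-231 cells (Homo sapiens) for cytotoxicity, read by MTT assay; on this read-out lower numbers stand for stronger inhibition and higher numbers for weaker inhibition
Compound 2 `COc1ccc(-n2cc(-c3ccc(N)cc3)nn2)cc1O`: > 10000 nM in this assay

In this assay compound 2 reached only a limit of the assay, (the limit of > 10000 nM in this assay, at which 1 of the 2 values shown sits), so no number is known for it. Compound 1 likewise gave only a limit, (the limit of > 1000 nM in this assay, at which 1 of the 2 values shown sits). For the measured compounds named here, with both values at limits, no measured step between them can be sized. Compound 3 `COc1ccc(-c2cn(-c3ccc(OC)c(O)c3)nn2)cc1` differs from compound 2 by methoxy in place of amino on an aromatic carbon. From two limits no direction can be read, and no step beyond the usual scatter is expected. Compound 3 is estimated at 20000 nM, within 5000 nM to 100000 nM, an expected step that the limit leaves unreadable from compound 2 to compound 3 in this assay.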

Compound 3, half-maximal inhibitory concentration: > 100 nM
Compound 3 was reported as a limit; the forecaster's own chance of this, stated with the estimate: 80%; the middle value lies beyond the limit too.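

For the compounds shown here, compound 1, compound 2 and compound 3 all gave only limits in this assay, and no step among them can be read. From the compounds shown here alone, the actual value of each compound, and how methoxy and amino compare, stay open.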